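This account rests on a few compounds, and the source may have more. Where it says the series, first, only, none or still open, it means among the compounds named here.

Series notes. Compound 3 `Cc1ccnc(/C(N)=N/NC(=S)N2CCSCC2)c1` and compound 1 `Cc1ccnc(/C(N)=N/NC(=S)N2CCOCC2)c1` share one core and differ only at the thiocarbonyl carbon; compound 2 `Cc1cccc(/C(N)=N/NC(=S)N2CCSCC2)n1` and compound 4 `Cc1cccc(/C(N)=N/NC(=S)N2CCOCC2)n1` share a second core, and the difference between the two cores is not broken down here. In a functional assay on A-431 cells (Homo sapiens) for cytotoxicity, read by MTT assay, with a stated time of 72 h, tested at 30 uM (on this read-out higher numbers stand for more inhibition of growth at the one concentration tested and lower numbers for less inhibition of growth), compound 3 gives 75.3% and compound 1 gives 74.6%. The change morpholin-4-yl in place of thiomorpholin-4-yl on a thiocarbonyl carbon produced the step of a number 0.7 percentage points lower from compound 3 to compound 1 (within the scatter). In this assay compound 2 gives 64.5%, the lowest of the three numbers measured, with its distance to compound 1 and to compound 3 beyond the scatter in both cases. Compound 4 has not yet been measured in this assay. The change morpholin-4-yl in place of thiomorpholin-4-yl on a thiocarbonyl carbon is the same change as that made from compound 3 to compound 1, the place being the same in both. The step from compound 2 to compound 4 is expected to be a number 0.5 percentage points lower from compound 2 to compound 4 (within the scatter), about as small as the earlier one, because the earlier step of a number 0.7 percentage points lower from compound 3 to compound 1 (within the scatter) lay within the scatter and nothing among the three measured compounds points to a larger shift. Compound 4 is therefore estimated at 64%, with a range from 52% to 76%.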

Compound 4, percent growth inhibition at one concentration: 80%
Estimate against measurement, compound 4: 16 percentage points below; measured number above the stated range.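

In this assay, morpholin-4-yl in place of thiomorpholin-4-yl on a thiocarbonyl carbon gives a number 15.5 percentage points higher from compound 2 to compound 4 (beyond the scatter), and this step does not match the one seen on the other core: the same change on two cores in this assay, a number 0.7 percentage points lower (within the scatter) from compound 3 to compound 1 and a number 15.5 percentage points higher (beyond the scatter) from compound 2 to compound 4, 16.2 percentage points apart, beyond the scatter of two such steps In this series, then, the step measured for this change on one core cannot be carried over as a prediction for the other, and the outcome of the exchange depends on the core that carries it. For the compounds shown here, this does not show why the two cores part, and it rests on only two matched pairs, read at one concentration on one cell line, so it gives no general rule for the exchange on any further core.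

Open, as far as these compounds go, is how a piperidin-1-yl or a dimethylamino group on the thiocarbonyl carbon would read on each of the two cores, and whether such groups would also differ from one core to the other. Also open, from the compounds shown here alone, is whether the gap between the two steps would hold in a full concentration-response measurement.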